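The compounds below may be only part of what the source reports. "The series", "measured", "known", "first", "only" and "open" are said of these compounds alone.

In a functional assay for inhibition (on this read-out higher numbers stand for weaker inhibition and lower numbers for stronger inhibition), two compounds with a shared core have been measured. Compound 1 `CC(C)(C)c1cc(-c2cc(=O)c3ccc(OCc4ccc(Cl)cc4)cc3o2)cc(C(C)(C)C)c1O` gives 7000 nM and compound 2 `CC(C)(C)c1cc(-c2cc(=O)c3ccc(O)cc3o2)cc(C(C)(C)C)c1O` gives 1000 nM as the lower of the two numbers, so compound 2 is the stronger inhibitor of the pair. Compound 3 `COc1ccc2c(=O)cc(-c3cc(C(C)(C)C)c(O)c(C(C)(C)C)c3)oc2c1` changes compound 2 on the same oxygen, as methyl in place of hydrogen on an oxygen on an aromatic ring with methyl in place of hydrogen on an oxygen on an aromatic ring, hydroxy to methoxy. For the measured compounds named here, the only measured step bearing on this is a 7.0-fold lower number from compound 1 to compound 2 (0.85 log units; beyond the scatter) with hydrogen in place of 4-chlorobenzyl on that oxygen. Methyl is much the smaller group, so a shift in the same direction but of lesser size is expected. In this assay the expected shift is a 2.5-fold higher number from compound 2 to compound 3 (0.40 log units; beyond the scatter) toward weaker inhibition. Compound 3 is estimated at 2500 nM with 800 nM to 7000 nM as the expected range.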

Compound 3, half-maximal inhibitory concentration: 1000 nM
The estimate for compound 3 lay 2.5-fold (0.40 log units) above the measured number; low and high end bracket the measured number.
By their numbers in this assay, from the lowest: compounds 2 and 3 (each within the scatter of the next); then compound 1.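

In this assay the oxygen on the aromatic ring accepts methyl in place of hydrogen, with no change at the digits printed from compound 2 to compound 3 (within the scatter), so capping this oxygen does not by itself raise the number. The rise seen with 4-chlorobenzyl thus goes with the larger group and not with the loss of the hydrogen, and it appears again as a 7.0-fold lower number from compound 1 to compound 3 (0.85 log units; beyond the scatter), where hydrogen stands in place of 4-chlorophenyl on the saturated chain carbon. Nothing available gives a reason for either step.

The compounds shown leave open where between methyl and 4-chlorobenzyl the number begins to rise, which an ethyl group, a longer chain or an unsubstituted benzyl group on this oxygen would help to place. They also leave open how a chain ending in an amine or a carboxylic acid would read here.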